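Chain extension from compound 2 to compound 3

A few compounds are considered here, and "the series" means these few. Any claim that something is new, unique, unknown or untested is made for them only; others in the source may bear on it.

Among the compounds with values here, compound 1 (`CNC(=O)CCCCCCCn1nc(-c2cnc3[nH]ccc3c2)c2c(N)ncnc21`) gives 5630 nM in a functional assay on HepG2 cells (Homo sapiens) for inhibition, read by MTT assay, with a stated time of 72 h (a lower number here means a stronger inhibitor, a higher number a weaker inhibitor), and is the only compound here with a measured number. Compound 2 (`Nc1nc2cc(-c3nn(CCCC(=O)NO)c4ncnc(N)c34)ccc2o1`) reads > 50000 nM in this assay and that value is a limit of the assay, not a number. Compound 3 (`Nc1nc2cc(-c3nn(CCCCCC(=O)NO)c4ncnc(N)c34)ccc2o1`) keeps the core of compound 2 and differs only in the chain. The change is 2-(hydroxycarbamoyl)ethyl in place of hydroxycarbamoyl on a saturated chain carbon, three bonds along the chain from an aromatic nitrogen on a saturated chain carbon, three bonds along the chain from an aromatic nitrogen. Cut further out, the same difference reads 3-(hydroxycarbamoyl)propyl to 5-(hydroxycarbamoyl)pentyl. Within the data shown here, no measured step in this set shows what such a change does, so the expectation is loose. Compound 1 at 5630 nM carries a different core and serves only as a rough numeric anchor. The estimated step of an at least 16-fold lower number from compound 2 to compound 3 (1.22 log units; beyond the scatter) is expected to run towards stronger inhibition and beyond the scatter, although the limit on compound 2 leaves its size open. Compound 3 is estimated at 3000 nM in this assay with an expected range from 400 nM to 25000 nM as the working figures.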

Compound 3, half-maximal inhibitory concentration: 1990 nM
Beside the measured number, compound 3's estimate is 1.5-fold (0.18 log units) above it, within the range that was stated.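

Within the data shown here, on the shared core, 2-(hydroxycarbamoyl)ethyl in place of hydroxycarbamoyl on a saturated chain carbon, three bonds along the chain from an aromatic nitrogen, gives the first readable step in this assay: an at least 25-fold lower number from compound 2 to compound 3 (1.40 log units; beyond the scatter). Compound 3 at 1990 nM also gives this core its first measured number, so the longer 5-(hydroxycarbamoyl)pentyl chain now serves as a reference for further changes at this position. The true size of the step stays open on one side, since compound 2 stands at a limit of the assay and not at a number: the limit of > 50000 nM in this assay, at which 1 of the 3 values shown sits.

With only these two chain lengths on this core, the compounds shown do not tell whether the change in this assay builds gradually through 4-(hydroxycarbamoyl)butyl or whether a still longer chain would continue it or reverse it. They also leave open whether the hydroxycarbamoyl end is needed at this chain length, which a carboxylic acid or a primary amide in its place on the same core would test.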